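The compounds below may be only part of what the source reports. "The series", "measured", "known", "first", "only" and "open" are said of these compounds alone.

Working notes on the series, values so far in an ADME assay on the whole organism (plasma) for pharmacokinetics, with Canis familiaris (Canis lupus familiaris) as the target, at a dose of 0.6 mg/kg by the oral route; on this read-out lower numbers stand for lower exposure and higher numbers for higher exposure at the dose given

compound 1 `CC[C@H](C)[C@@H]1C(=O)N[C@H](C2Cc3ccccc3C2)C(=O)N1[C@@H](C(=O)N(C)C)c1ccc(C)nc1C` gives 305 ng.h/mL as measured
compound 2 `CC[C@@H](C)[C@@H]1C(=O)N[C@H](C2Cc3ccccc3C2)C(=O)N1[C@@H](C(=O)N1CCOCC1)c1ccc(C)nc1` gives 138 ng.h/mL as measured

Compound 2 holds the lower of the two numbers, and the gap up to compound 1 lies beyond the usual scatter. The next compound is compound 3 `CC[C@H](C)[C@@H]1C(=O)N[C@H](C2Cc3ccccc3C2)C(=O)N1[C@@H](C(=O)N1CCOCC1)c1ccc(C)nc1`, which has the same atoms and bonds as compound 2 and differs only in configuration as drawn (the two compounds have the same atoms and bonds and differ only in configuration as drawn: 1 of 4 stereo elements differ; a stereocentre at a saturated chain carbon is drawn R in compound 2 and S in compound 3). Among the measured compounds shown here, no measured pair differs in one place, so the data give no direct guide to the size of such a change. In this assay no step beyond the scatter is expected, with only a slight lean upward. The estimated step (a 1.2-fold higher number from compound 2 to compound 3 (0.09 log units; within the scatter)) stays within that scatter. For compound 3 the estimated value is 170 ng.h/mL with an expected range from 70 ng.h/mL to 420 ng.h/mL on this read-out.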

Compound 3, area under the concentration-time curve: 55 ng.h/mL
Compound 3: the middle estimate sits 3.1-fold (0.49 log units) above what was measured; the whole stated range lies above it.
By their numbers in this assay, from the lowest: compound 3; then compound 2; then compound 1.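

In this assay, the series now has its first step between compounds that differ in one place: a 2.5-fold lower number from compound 2 to compound 3 (0.40 log units; beyond the scatter). This step lies beyond the scatter, so exposure in this pair responds to configuration at the saturated chain carbon, with the form drawn R higher than the form drawn S. The comparison isolates this stereocentre, with no atom or bond changed: the fact that compounds 2 and 3 differ only in the configuration as drawn

As far as these compounds go, it remains open whether the same inversion gives a similar step in other members, as compound 1, at 305 ng.h/mL, differs from compound 3 in more than one place and cannot test this. The compounds shown also leave open how exposure would respond to a longer chain or an amine at this carbon, and which process underlies the lower exposure of compound 3.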